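The source may report more compounds than this note shows. Statements on the series, on what has been measured and on what is new or still open speak of the compounds shown alone.

Measured compounds:
compound 1 `CCCCCCNC(=O)n1cc(Cl)c(=O)[nH]c1=O` — 67 nM
compound 2 `CCCCCCNC(=O)n1cc(NC)c(=O)[nH]c1=O` — 3400 nM
compound 3 `CCCCCCNC(=O)n1cc(F)c(=O)n(CC)c1=O` — 18 nM

In an assay on HEK293 cells for inhibition of acid ceramidase (Rattus norvegicus), read by LC-MS, with a stated time of 30 min (on this read-out higher numbers stand for weaker inhibition and lower numbers for stronger inhibition), compound 3 gives the lowest of the three numbers; compound 1 sits nearer to it, compound 2 far away. Compound 4 `CCCCCCNC(=O)n1cc(F)c(=O)n(C(=O)c2ccccc2)c1=O` is compound 3 with benzoyl in place of ethyl on an aromatic nitrogen. Among the compounds with values here, the one measured step, a 51-fold higher number from compound 1 to compound 2 (1.71 log units; beyond the scatter), concerns a change at an aromatic carbon, not at the ring nitrogen, so it does not bear directly on this change. Within the data shown here, compound 1 and compound 3 differ in two places at once, so their values show only that the pair differs. Among the measured compounds shown here, with no step at the ring nitrogen to lean on, the expected step for compound 4, a 2.2-fold higher number from compound 3 to compound 4 (0.35 log units; beyond the scatter), is set small and uncertain. Compound 4 is estimated at 40 nM, within 8 nM to 200 nM.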

Compound 4, half-maximal inhibitory concentration: 20 nM
Estimate against measurement, compound 4: 2.0-fold (0.30 log units) above; the measured number falls inside the stated range.
By their numbers in this assay, from the lowest: compounds 3 and 4 (each within the scatter of the next); then compound 1; then compound 2.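

Putting benzoyl in place of ethyl on the aromatic nitrogen gives, in this assay, a 1.1-fold higher number from compound 3 to compound 4 (0.05 log units; within the scatter), so this position accepts a group of 8 heavy atoms with an aromatic ring as well as one of 2 heavy atoms. Until now, ethyl was the only group shown there. Nothing measured here explains why the two groups read alike.

From the compounds shown here alone, whether a carboxylic acid, an amine or a longer carbon chain on this nitrogen would read the same remains open. So does whether benzoyl would behave alike with chloro in place of fluoro.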